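A few compounds are considered here, and "the series" means these few. Any claim that something is new, unique, unknown or untested is made for them only; others in the source may bear on it.

In a toxicity assay on HeLa cells (Homo sapiens) for cytotoxicity, read by MTT assay, with a stated time of 24 h (a higher number here means a weaker inhibitor, a lower number a stronger inhibitor), compound 3 `CCCCN1CCN(C(=S)SCC(O)Cn2cc([N+](=O)[O-])nc2C)CC1` gives 4330000 nM, the highest of the two numbers measured here. Its nearest neighbour is compound 1 `Cc1nc([N+](=O)[O-])cn1CC(O)CSC(=S)N1CCN(c2cccc(Cl)c2Cl)CC1`, which gives 724000 nM; the step of a 6.0-fold higher number from compound 1 to compound 3 (0.78 log units; beyond the scatter) comes with butyl in place of 2,3-dichlorophenyl on an amine nitrogen in a ring. Compound 2 `CCN1CCN(C(=S)SCC(O)Cn2cc([N+](=O)[O-])nc2C)CC1` reaches only a limit of the assay, > 5000000 nM, namely (the limit of > 5000000 nM in this assay, at which 1 of the 3 values shown sits). The step of an at least 1.1-fold lower number from compound 2 to compound 3 (0.06 log units; that floor lies within the scatter), ethyl in place of hydrogen on a saturated chain carbon two bonds from that ring nitrogen, does not separate the two.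

Compound 4 `CCOC(=O)N1CCN(C(=S)SCC(O)Cn2cc([N+](=O)[O-])nc2C)CC1` has not yet been measured. It differs from compound 3 by ethoxycarbonyl in place of butyl on an amine nitrogen in a ring. For the measured compounds named here, no measured step exchanges an alkyl group for an ethoxycarbonyl group, so only indirect guidance exists: the two alkyl-bearing compounds 2 and 3 both sit at or near the upper end of the numbers, and the step of a 6.0-fold higher number from compound 1 to compound 3 (0.78 log units; beyond the scatter) shows that removing the 2,3-dichlorophenyl raised the number. The expected change is therefore small, a 1.1-fold lower number from compound 3 to compound 4 (0.03 log units; within the scatter), with a real chance that only a limit is read. For compound 4 the estimate is 4000000 nM, ranging from 1200000 nM to 12000000 nM.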

Compound 4, half-maximal inhibitory concentration: 2360000 nM
Estimate against measurement, compound 4: 1.7-fold (0.23 log units) above; low and high end bracket the measured number.
By their numbers in this assay, from the lowest: compound 1; then compounds 4 and 3 (each within the scatter of the next). At a limit, above all of these: compound 2.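

Replacing an alkyl group on this ring nitrogen with a carbonyl-bearing group does not clearly change the reading in this assay, since the comparison with butyl gives a 1.8-fold lower number from compound 3 to compound 4 (0.26 log units; within the scatter). The comparison with ethyl gives an at least 2.1-fold lower number from compound 2 to compound 4 (0.32 log units; beyond the scatter), and the comparison with the aromatic substituent gives a 3.3-fold higher number from compound 1 to compound 4 (0.51 log units; beyond the scatter), so ethoxycarbonyl joins ethyl and butyl in reading higher than 2,3-dichlorophenyl, with no listed compound going against this. Compound 2 is read only at a limit, so its step to compound 4 gives a minimum rather than a measured size: the limit of > 5000000 nM in this assay, at which 1 of the 4 values shown sits.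

The compounds shown leave open whether the lower number of compound 1 comes with an aromatic ring on this nitrogen as such or with its two chlorine atoms, a question that an unsubstituted phenyl would address. They also leave open how this position responds to a charged group such as a carboxylic acid or a primary amine at the end of a longer chain.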